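Moving One Methoxy Group: From Compound 3 to Compound 4

The compounds below may be only part of what the source reports. "The series", "measured", "known", "first", "only" and "open" are said of these compounds alone.

In a functional assay on MDA-MB-436 cells (Homo sapiens) for antiproliferative activity, read by MTT assay, with a stated time of 48 h (on this read-out lower numbers stand for stronger inhibition and higher numbers for weaker inhibition), compound 1 `C=CS(=O)(=O)N1CCN(c2ncnc3sc(-c4cnn(Cc5ccccc5)c4)cc23)CC1` gives 18300 nM while compound 2 `CCCNC(=O)N1CCN(c2ncnc3sc(-c4ccc(N5CCN(C)CC5)cc4)cc23)CC1` gives 12400 nM and compound 3 `COc1ccc(NC(=O)N2CCN(c3ncnc4sc(-c5ccc(N6CCN(C)CC6)cc5)cc34)CC2)cc1` gives 30100 nM as its measured value. Compound 3 therefore sits within the usual scatter of compound 1 and clearly above compound 2.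

Compound 4 `COc1ccccc1NC(=O)N1CCN(c2ncnc3sc(-c4ccc(N5CCN(C)CC5)cc4)cc23)CC1` has the same atoms as compound 3, joined differently: 2-methoxyphenyl stands in place of 4-methoxyphenyl on an amide-type nitrogen (2-methoxyphenyl in place of 4-methoxyphenyl on an amide-type nitrogen).

Going by the values given here, one measured step bears on this nitrogen. Putting 4-methoxyphenyl in place of propyl gave a 2.4-fold higher number from compound 2 to compound 3 (0.39 log units; beyond the scatter) and so even swapping the whole group made only a modest difference. Among the compounds with values here, no measured pair shows the methoxy group moved, so this guide is indirect.

The expected step is a 1.2-fold lower number from compound 3 to compound 4 (0.08 log units; within the scatter) in this assay and so no change beyond the scatter is anticipated. Compound 4 is estimated at 25000 nM with an expected range from 10000 nM to 60000 nM in this measurement.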

Compound 4, half-maximal inhibitory concentration: 26300 nM
Beside the measured number, compound 4's estimate is 1.1-fold (0.02 log units) below it; the measured number falls inside the stated range.
By their numbers in this assay, from the lowest: compounds 2, 1, 4 and 3 (each within the scatter of the next, the first and the last beyond it).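

Moving the methoxy group gives a 1.1-fold lower number from compound 3 to compound 4 (0.06 log units; within the scatter) in this assay, so at this amide-type nitrogen the 2-methoxyphenyl and 4-methoxyphenyl groups cannot be told apart on this read-out. Set against propyl, the 2-methoxyphenyl group gives a 2.1-fold higher number from compound 2 to compound 4 (0.33 log units; beyond the scatter), a modest step that agrees with the one already seen for 4-methoxyphenyl, so both methoxyphenyl compounds stand apart from the propyl compound by a similar small margin. No measurement at hand offers an explanation for either result.

The compounds shown leave open whether a phenyl ring carrying an amine or a carboxylic acid in place of methoxy, or a plain phenyl ring, would read differently at this nitrogen. They also leave open whether a chain longer than propyl, such as hexyl, would move the number in either direction.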